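A few compounds are considered here, and "the series" means these few. Any claim that something is new, unique, unknown or untested is made for them only; others in the source may bear on it.

Going by the values given here, in a functional assay on HepG2 cells (Homo sapiens) for inhibition, read by scintillation counting, with a stated time of 2 h (a higher number here means a weaker inhibitor, a lower number a stronger inhibitor), compound 1 `CC(=O)N1CCC(C(=O)N2CCC(N3CCN(C(=O)c4cc(-c5ccc(C)cc5)nc(-c5ccc6[nH]c(C)c(C)c6c5)c4)CC3)CC2)CC1` gives 294 nM as the only number so far. Compound 2 `CCCCC(=O)N1CCC(N2CCN(C(=O)c3c(NC(=O)NCC)sc4ccccc34)CC2)CC1` stands at "not determined" (no result reported) and compound 3 `CCNC(=O)Nc1sc2ccccc2c1C(=O)N1CCN(C2CCN(C(=O)C(C)C)CC2)CC1` likewise at "not determined" (no result reported) here, so compound 3 has no place on the scale yet. The next step leads to compound 4 `CCNC(=O)Nc1sc2ccccc2c1C(=O)N1CCN(C2CCN(C(=O)OC3CCCCC3)CC2)CC1` with cyclohexyloxy in place of isopropyl on a carbonyl carbon, counted as cyclohexyloxy in place of isopropyl on a carbonyl carbon in full. Among the compounds with values here, no measured pair shows what such a change does, so no step beyond the scatter is expected in this assay and no direction is favoured. Within the data shown here, the only numerical anchor is compound 1 at 294 nM and its structure differs widely. Compound 4 is expected near 300 nM with an estimated range from 50 nM to 2000 nM in this measurement.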

Compound 4, half-maximal inhibitory concentration: 635 nM
The estimate for compound 4 lay 2.1-fold (0.33 log units) below the measured number; measured number inside the range.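

In this assay no step can be read between compound 3 and compound 4. The compounds shown leave open what cyclohexyloxy in place of isopropyl on a carbonyl carbon does to inhibition. No evidence bears on this result.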